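This account rests on a few compounds, and the source may have more. Where it says the series, first, only, none or still open, it means among the compounds named here.

Measured in a functional assay on MCF7 cells (Homo sapiens) for antiproliferative activity, read by MTT assay, with a stated time of 72 h; on this read-out lower numbers stand for stronger inhibition and higher numbers for weaker inhibition:
compound 1 `COc1cc(-n2cnc3ccc(-c4cc(F)ccc4F)cc32)cc(OC)c1OC`: 6420 nM
compound 2 `COc1cc(-n2cnc3ccc(-c4ccccc4)cc32)cc(OC)c1OC`: 2290 nM
compound 3 `COc1cc(-n2cnc3ccc(-c4cccc([N+](=O)[O-])c4)cc32)cc(OC)c1OC`: 4560 nM

Compound 3 lies within the scatter of both other compounds, so no order can be drawn around it. The only separation beyond the scatter in this set is a 2.8-fold lower number from compound 1 to compound 2 (0.45 log units; beyond the scatter), and it is modest.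

The next compound is compound 4 `COc1cc(-n2cnc3ccc(-c4ccc(O)cc4)cc32)cc(OC)c1OC`, not yet measured. The change is 4-hydroxyphenyl in place of 3-nitrophenyl on an aromatic carbon, with 4-hydroxyphenyl in place of 3-nitrophenyl on an aromatic carbon. Within the data shown here, no measured compound carries 4-hydroxyphenyl, so no step covers the entering group directly. The closest evidence is the exchange of groups at the same place. Nitro in place of hydrogen gave a 2.0-fold higher number from compound 2 to compound 3 (0.30 log units; within the scatter), and 3-nitrophenyl in place of 2,5-difluorophenyl gave a 1.4-fold lower number from compound 1 to compound 3 (0.15 log units; within the scatter). Both lie within the scatter. Among these three compounds, no exchange went further than a 2.8-fold lower number from compound 1 to compound 2 (0.45 log units; beyond the scatter).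

A change of that modest size is therefore the most expected in this assay, with a slight lean towards compound 2 at 2290 nM. The estimated step is a 1.5-fold lower number from compound 3 to compound 4 (0.18 log units; within the scatter), and no change beyond the scatter is expected. For compound 4 the expected value is 3000 nM, with an estimated range of 1100 nM to 8000 nM.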

Compound 4, half-maximal inhibitory concentration: 4160 nM
The estimate for compound 4 lay 1.4-fold (0.14 log units) below the measured number; the measured number falls inside the stated range.
By their numbers in this assay, from the lowest: compounds 2, 4, 3 and 1 (each within the scatter of the next, the first and the last beyond it).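

Across the exchanges at this aromatic carbon, 4-hydroxyphenyl adds a group with a hydrogen-bond donor to a set that had none, and in this assay it cannot be told apart from any of the three other groups: from 3-nitrophenyl (a 1.1-fold lower number from compound 3 to compound 4 (0.04 log units; within the scatter)), from unsubstituted phenyl (a 1.8-fold higher number from compound 2 to compound 4 (0.26 log units; within the scatter)) and from 2,5-difluorophenyl (a 1.5-fold lower number from compound 1 to compound 4 (0.19 log units; within the scatter)). Hydroxy in place of hydrogen thus joins nitro in place of hydrogen as a change that stays within the scatter, and the one separation beyond it remains that of the two end compounds (a 2.8-fold lower number from compound 1 to compound 2 (0.45 log units; beyond the scatter)), now with compound 3 and compound 4 each unresolved from both. Nothing measured on these groups bears on this flat reading, and no account of it can be offered.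

Still open, from the compounds shown here alone, is whether an amine or a carboxylic acid on the phenyl ring, or a saturated ring such as cyclohexyl in place of the phenyl ring, would move the number clearly beyond the scatter. Going by these compounds, it is also open whether 3-hydroxyphenyl would read like 4-hydroxyphenyl in this assay.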